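Swapping the aryl azole for a cyanopyridine

The compounds below may be only part of what the source reports. "The series", "measured", "known", "first", "only" and "open" are said of these compounds alone.

Compound 1 `CCC(C)(C)Cc1c[nH]c(CCc2ccc(-n3cccn3)cc2)n1` gives 33 nM in an in vitro assay on CHO cells for displacement of a labelled ligand from Bombesin receptor subtype-3 (Homo sapiens), read by scintillation counting, with a stated time of 2 h; a lower number here means a stronger inhibitor, a higher number a weaker inhibitor.
Compound 2 `CCC(C)(C)Cc1c[nH]c(CCc2ccc(-n3ncnn3)cc2)n1` gives 205 nM in this assay.
Compound 3 `CCC(C)(C)Cc1c[nH]c(CCc2ccc(-n3ccnn3)cc2)n1` gives 390 nM in this assay.

Compound 3 has the highest number of the three, the weakest binding shown so far. Its gap to compound 2 is within the scatter (a 1.9-fold higher number from compound 2 to compound 3 (0.28 log units; within the scatter)), but the step that begins at compound 1 is clearly beyond the scatter (a 12-fold higher number from compound 1 to compound 3 (1.07 log units; beyond the scatter)).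

Compound 4 `CCC(C)(C)Cc1c[nH]c(CCc2ccc(-c3cccc(C#N)n3)cc2)n1` changes the group on the aromatic carbon of the carbon-only six-membered ring, para to a large group: 6-cyanopyridin-2-yl in place of 1H-1,2,3-triazol-1-yl on an aromatic carbon. Among the compounds with values here, none of the measured steps replaces this ring with a six-membered one, so no direct comparison exists. What the measured steps do show is that the group at this position matters: moving from 1H-pyrazol-1-yl to 2H-tetrazol-2-yl gave a 6.2-fold higher number from compound 1 to compound 2 (0.79 log units; beyond the scatter), and to 1H-1,2,3-triazol-1-yl gave a 12-fold higher number from compound 1 to compound 3 (1.07 log units; beyond the scatter), while the two weaker rings differ only within the scatter. A new ring type could therefore move the number either way, and the whole measured span is plausible.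

For compound 4 the expected result in this assay is 90 nM, within a range of 15 nM to 600 nM, and the expected step is a 4.3-fold lower number from compound 3 to compound 4 (0.64 log units; beyond the scatter).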

Compound 4, half-maximal inhibitory concentration: 140 nM
Compound 4: middle estimate off by 1.6-fold (0.19 log units), on the low side; the range from low to high includes it.
By their numbers in this assay, from the lowest: compound 1; then compounds 4, 2 and 3 (each within the scatter of the next, the first and the last beyond it).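

Replacing the five-membered ring with a larger six-membered one carrying a nitrile is tolerated at this position. In this assay, the change from the triazole gives a modest gain beyond the scatter (a 2.8-fold lower number from compound 3 to compound 4 (0.44 log units; beyond the scatter)), while the step from the tetrazole stays within the scatter (a 1.5-fold lower number from compound 2 to compound 4 (0.17 log units; within the scatter)), so compound 4 cannot be told apart from compound 2. The 1H-pyrazol-1-yl group still binds best of the four, and 6-cyanopyridin-2-yl does not match it (a 4.2-fold higher number from compound 1 to compound 4 (0.63 log units; beyond the scatter)), but nothing here gives a measured reason for any of these differences.

On these data alone, compound 4 brings in the pyridine nitrogen and the nitrile together, so the share of each in the result stays open; a plain pyridin-2-yl group or a 3-cyanophenyl group would separate the two. As far as these compounds go, it is also open whether a different group on the pyridine, such as a methyl or an amine in place of the nitrile, could bring the number down to that of compound 1 at 33 nM.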